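Ester in place of ethylamino on the fused core

A few compounds are considered here, and "the series" means these few. Any claim that something is new, unique, unknown or untested is made for them only; others in the source may bear on it.

Measured so far:
compound 1, `Cc1nc2c(OCc3ccc(C(F)(F)F)cc3)cccn2c1N`, gives 78%
compound 2, `Cc1nc2c(COc3ccccc3)cccn2c1N`, gives 27%
compound 3, `CCNc1c(C)nc2c(CCc3ccccc3)cccn12`, gives 78%

All three were run in a functional assay on the whole organism with Rattus norvegicus as the target, at a dose of 40 mg/kg by the intraperitoneal route; on this read-out higher numbers stand for more inhibition at the one dose given (going by the name of the read-out) and lower numbers for less inhibition. Compound 3 stands level with compound 1 at the digits shown, and the two together hold the highest of the three numbers; the gap between them lies within the scatter, so no order between compound 1 and compound 3 can be stated. Compound 2 is the furthest from compound 3, its number lower by an amount beyond the scatter. Within the data shown here, no two measured compounds differ in one place only, so no step of a single change is available from the measured set.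

Compound 4, `COC(=O)c1c(C)nc2c(CCc3ccccc3)cccn12`, is the next compound for this assay. It differs from compound 3 in one place: methoxycarbonyl in place of ethylamino on an aromatic carbon. The change removes the one hydrogen-bond donor of the ethylamino group and adds an acceptor. Among the measured compounds shown here, no measured compound carries a group without a hydrogen-bond donor at the place of the change, so the data show nothing directly about this substitution. With nothing to anchor the change, a decrease beyond the scatter is expected as the step of a number 33 percentage points lower from compound 3 to compound 4 (beyond the scatter), with wide uncertainty. Compound 4 is estimated to give 45%, within a range from 15% to 75%.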

Compound 4, a percentage reported as inhibition, in the whole organism at one dose (the size of the read-out at that dose, not a potency): 64%
Beside the measured number, compound 4's estimate is 19 percentage points below it; the measured number falls inside the stated range.
By their numbers in this assay, from the lowest: compound 2; then compound 4; then compounds 1 and 3 (each within the scatter of the next).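

In this assay, methoxycarbonyl in place of ethylamino on this aromatic carbon gives a number 14 percentage points lower from compound 3 to compound 4 (beyond the scatter), the first single-place step available in the series. The step shows that a hydrogen-bond donor at this place is not needed for substantial inhibition at the one dose given, since compound 4, with 0 hydrogen-bond donors, still gives 64%, although the ethylamino compound holds the higher number. Nothing on hand accounts for the size of the step.

This single exchange removes the donor, adds acceptors and enlarges the group all at once, so these changes cannot be told apart; a carboxylic acid, an ethyl ester or an unsubstituted amide at the same place on the shared core, each read against compound 3 and compound 4, would begin to separate them. Going by these compounds, it also remains open whether the same exchange gives a step of similar size when the phenethyl-type side chain of these two compounds is replaced by a longer chain.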